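Heteroaryl Exchange on the Sulfonamide Nitrogen of Compound 2

The compounds below may be only part of what the source reports. "The series", "measured", "known", "first", "only" and "open" are said of these compounds alone.

Two compounds of this series carry a result in a functional assay on A549 cells (Homo sapiens) for cytotoxicity, read by sulforhodamine B assay, with a stated time of 72 h; on this read-out higher numbers stand for weaker inhibition and lower numbers for stronger inhibition. Compound 1 `CCOC1Oc2ccccc2C(=O)/C1=C/Nc1ccc(S(=O)(=O)Nc2cc(C)on2)cc1` gives 57200 nM in this assay. Compound 2 `Cc1cc(NS(=O)(=O)c2ccc(NC3=NC(=O)/C(=C\c4coc5ccccc5c4=O)S3)cc2)no1` returns only a limit of the assay, > 100000 nM, so no number is available for it. Compound 2 therefore stands at the limit of what has been measured, and the limit of > 100000 nM in this assay, at which 1 of the 2 values shown sits, records that a limit rather than a value is the outcome for one of the two compounds. Among the compounds with values here, no pair of measured compounds differs in only one place, so no measured step can be quoted.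

Compound 3 `Cc1cc(C)nc(NS(=O)(=O)c2ccc(NC3=NC(=O)/C(=C\c4coc5ccccc5c4=O)S3)cc2)n1` is the next member, not yet measured in this assay. It differs from compound 2 in one place: 4,6-dimethylpyrimidin-2-yl in place of 5-methyl-1,2-oxazol-3-yl on a sulfonamide nitrogen. Compound 1 also sits at weak inhibition, and compound 2 is at the limit, so nothing measured points to a move beyond the scatter. Compound 3 is expected to stay near the limit, with a step that the limit leaves unreadable from compound 2 to compound 3 expected to lie within the scatter. The estimate for compound 3 is 110000 nM, with a range from 40000 nM to 300000 nM, and a limit rather than a number is considered likely.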

Compound 3, half-maximal inhibitory concentration: > 100000 nM
Compound 3: only a limit was reported; the forecaster's own chance of this, stated with the estimate: 60%; the middle value does not contradict the limit.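

Compound 2 and compound 3 each return only a limit of the assay in this assay, so no step between them can be read: the limit of > 100000 nM in this assay, at which 2 of the 3 values shown sit.

Left open is whether 4,6-dimethylpyrimidin-2-yl in place of 5-methyl-1,2-oxazol-3-yl on a sulfonamide nitrogen shifts inhibition at all in this assay.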